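The source may report more compounds than this note shows. Statements on the series, on what has been measured and on what is new or still open speak of the compounds shown alone.

Values in a functional assay on HepG2 cells (Homo sapiens) for cytotoxicity, read by MTT assay, with a stated time of 72 h; on this read-out higher numbers stand for weaker inhibition and lower numbers for stronger inhibition:
- Compound 1 `CC[S+]([O-])CCCCN=C=S`: 5350 nM
- Compound 2 `CCCC[S+]([O-])CCCCN=C=S`: 5930 nM
- Compound 3 `CC(C)C[S+]([O-])CCCCN=C=S`: 2160 nM

Compound 3 stands lowest of the three, and both steps that reach it are modest but beyond the scatter: a 2.5-fold lower number from compound 1 to compound 3 (0.39 log units; beyond the scatter), and a 2.7-fold lower number from compound 2 to compound 3 (0.44 log units; beyond the scatter). The remaining step, a 1.1-fold higher number from compound 1 to compound 2 (0.04 log units; within the scatter), stays within the scatter.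

Compound 4 `[O-][S+](CCCCN=C=S)Cc1cccs1` has thiophen-2-yl in place of isopropyl on a saturated chain carbon bound to a sulfur. Among the measured compounds shown here, none of the measured compounds carries a ring at this place, so the steps bear on the change only indirectly. They do show that exchanges at this end of the molecule have so far moved the number little, the largest being a 2.7-fold lower number from compound 2 to compound 3 (0.44 log units; beyond the scatter). Compound 4 gives up the isopropyl found in compound 3, so a small move back to a higher number in this assay is expected, not clearly beyond the scatter. The expected step is a 1.8-fold higher number from compound 3 to compound 4 (0.25 log units; within the scatter). For compound 4 the estimated value is 3800 nM, with an expected range from 1600 nM to 8500 nM.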

Compound 4, half-maximal inhibitory concentration: 3820 nM
The estimate for compound 4 lay 1.0-fold (0.00 log units) below the measured number; the measured number falls inside the stated range.
By their numbers in this assay, from the lowest: compounds 3, 4, 1 and 2 (each within the scatter of the next, the first and the last beyond it).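

Compound 4 shows that this place, a saturated chain carbon bound to a sulfur, also accepts a five-membered aromatic ring: in this assay thiophen-2-yl in place of isopropyl gives a 1.8-fold higher number from compound 3 to compound 4 (0.25 log units; within the scatter) and so does not separate compound 4 from compound 3. The other two exchanges also stay within the scatter, with a 1.6-fold lower number from compound 2 to compound 4 (0.19 log units; within the scatter) for thiophen-2-yl in place of propyl and a 1.4-fold lower number from compound 1 to compound 4 (0.15 log units; within the scatter) for thiophen-2-yl in place of methyl, so compound 4 cannot be told apart from any of the three earlier compounds. Nothing given here accounts for these numbers.

One ring says little about rings in general, and a phenyl or a furan-2-yl group could behave differently at this place. From the compounds shown here alone, how an amine or a carboxylic acid would fare there also remains open.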